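The source may report more compounds than this note shows. Statements on the series, on what has been measured and on what is new or still open speak of the compounds shown alone.

Working notes on the series. In a functional assay on DU-145 cells (Homo sapiens) for inhibition, read by trypan blue exclusion, with a stated time of 96 h (on this read-out lower numbers stand for stronger inhibition of growth and higher numbers for weaker inhibition of growth), compound 1 `CSc1ccc(/C=C(/SCc2ccc(C)cc2)C(=O)c2ccc(Cl)cc2)cc1` gives 25000 nM, compound 2 `COc1ccccc1/C=C(/SCc1ccc(C)cc1)C(=O)c1ccc(Cl)cc1` gives 10000 nM and compound 3 `Cc1ccc(CS/C(=C/c2ccc(C)s2)C(=O)c2ccc(Cl)cc2)cc1` gives 50000 nM. The three compounds differ only in the group on a double-bonded chain carbon bound to a double-bonded chain carbon. Compound 3 cannot be separated from compound 1, as shown by a 2.0-fold higher number from compound 1 to compound 3 (0.30 log units; within the scatter). Compound 2 stands apart from both, with a 2.5-fold lower number from compound 1 to compound 2 (0.40 log units; beyond the scatter) and a 5.0-fold higher number from compound 2 to compound 3 (0.70 log units; beyond the scatter).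

Compound 4 `Cc1ccc(CS/C(=C/c2ccccc2Br)C(=O)c2ccc(Cl)cc2)cc1` differs from compound 3 by a single change: 2-bromophenyl in place of 5-methylthiophen-2-yl on a double-bonded chain carbon bound to a double-bonded chain carbon. The 2-bromophenyl group has not yet been measured in this series, so any expectation rests on three compounds only. The closest comparison is compound 2, which carries 2-methoxyphenyl where compound 3 carries 5-methylthiophen-2-yl. Read in reverse, a 5.0-fold higher number from compound 2 to compound 3 (0.70 log units; beyond the scatter) suggests a lower number when 5-methylthiophen-2-yl leaves for a substituted phenyl. Compound 1 gives a weaker signal, since a 2.0-fold higher number from compound 1 to compound 3 (0.30 log units; within the scatter) stays within the scatter. Only part of the compound 2 gain is therefore carried over. The expected step is a 3.3-fold lower number from compound 3 to compound 4 (0.52 log units; beyond the scatter), a modest move towards stronger inhibition of growth. Compound 4 is estimated at 15000 nM, with an expected range of 5000 nM to 40000 nM.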

Compound 4, concentration for 50% growth inhibition: 10000 nM
For compound 4 the middle estimate is 1.5-fold (0.18 log units) above the measured one, within the range that was stated.
By their numbers in this assay, from the lowest: compounds 2 and 4 (each within the scatter of the next); then compounds 1 and 3 (each within the scatter of the next).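

The 2-bromophenyl group moves the series clearly away from 5-methylthiophen-2-yl at this position, with a 5.0-fold lower number from compound 3 to compound 4 (0.70 log units; beyond the scatter) in this assay, and also away from 4-(methylsulfanyl)phenyl, with a 2.5-fold lower number from compound 1 to compound 4 (0.40 log units; beyond the scatter) as the step. Bromo and methoxy on the aromatic carbon cannot be told apart, with no change at the digits printed from compound 2 to compound 4 (within the scatter), so 2-bromophenyl and 2-methoxyphenyl now form one level among the four compounds, while compound 1 shows that a substituted phenyl at this position does not by itself reach that level. No measurement is available that would explain these differences.

The four compounds do not show whether this level is kept when an amine, a carboxylic acid or a longer chain such as ethoxy takes the place of bromo or methoxy on that aromatic carbon, or whether a phenyl group carrying no substituent falls with compound 2 and compound 4 or with compound 1 and compound 3. Going by these compounds, the rest of the shared core is the same throughout, so it also stays open whether this order of groups would hold with a different group on the sulfur or on the carbonyl.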